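Removing the benzyl trifluoromethyl in a sulfonyl-amidine series

The source may report more compounds than this note shows. Statements on the series, on what has been measured and on what is new or still open speak of the compounds shown alone.

The series concerns cytotoxicity read in a functional assay on HCT-116 cells (Homo sapiens) for cytotoxicity, read by MTT assay, with a stated time of 72 h; on this read-out higher numbers stand for weaker inhibition and lower numbers for stronger inhibition. Compound 1 `Cc1cc(-c2ccccc2)n(/C(N)=N/S(=O)(=O)c2cc(C)c(Cl)cc2SCc2ccccc2C(F)(F)F)n1` gives 25000 nM, the highest of the three numbers in hand. Compound 2 `Cc1cc(S(=O)(=O)/N=C(\N)n2nccc2-c2ccccc2)c(SCc2cccc(Cl)c2)cc1Cl` gives 7000 nM, and compound 3 `Cc1cc(S(=O)(=O)/N=C(\N)n2nccc2-c2ccccc2)c(SCc2cccc(C(F)(F)F)c2)cc1Cl` gives 14000 nM; these two share a core that differs from that of compound 1, and compound 1 sits a distance from compound 3 that lies within the scatter, while its distance from compound 2 lies beyond it.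

The step from compound 1 to compound 4 `Cc1cc(-c2ccccc2)n(/C(N)=N/S(=O)(=O)c2cc(C)c(Cl)cc2SCc2ccccc2)n1` is hydrogen in place of trifluoromethyl on an aromatic carbon. For the measured compounds named here, the only measured step that touches the benzylsulfanyl group is a 2.0-fold higher number from compound 2 to compound 3 (0.30 log units; within the scatter), and it swapped one substituent for another on a different carbon of that ring, so it is not the same change. It does show that altering the substitution on this ring left the number within the scatter. Going by the values given here, no measured pair shows the loss of a substituent to hydrogen.

The step from compound 1 to compound 4 is therefore expected to be small, a 1.4-fold lower number from compound 1 to compound 4 (0.14 log units; within the scatter), within the usual scatter. Compound 4 is estimated at 18000 nM in this assay, with a likely range from 8000 nM to 45000 nM.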

Compound 4, half-maximal inhibitory concentration: 10000 nM
Beside the measured number, compound 4's estimate is 1.8-fold (0.26 log units) above it; low and high end bracket the measured number.
By their numbers in this assay, from the lowest: compounds 2, 4, 3 and 1 (each within the scatter of the next, the first and the last beyond it).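

In this assay, the change gives the first measured loss of a substituent to hydrogen on this benzyl ring, a 2.5-fold lower number from compound 1 to compound 4 (0.40 log units; beyond the scatter), a modest step. The earlier step on this ring, a 2.0-fold higher number from compound 2 to compound 3 (0.30 log units; within the scatter), swapped one substituent for another on a different carbon and stayed within the scatter, whereas this change, on an aromatic carbon ortho to a large group, goes beyond it, so within this pair the trifluoromethyl is not needed for the cytotoxicity seen and the plain benzylsulfanyl group gives the lower number. Nothing in the information at hand accounts for the size of this step.

The compounds shown leave open whether another group at this place, such as methyl, methoxy, fluoro or a carboxylic acid, would give a number closer to that of compound 1 or of compound 4. They also leave open whether hydrogen in place of trifluoromethyl on the benzyl ring of compound 3, where the group sits on a different carbon and the core differs, would give a step of similar size.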